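A Fourth Amide on a Shared Core

The source may hold more compounds than are shown below. What is called first, only, known or untested is meant among the compounds shown, and "the series" means these compounds.

Compound 1 `COc1ccc2c(=O)c(/C=C/C(=O)Nc3cccc(Cl)c3)coc2c1` carries a 3-chlorophenyl on an amide-type nitrogen. In a functional assay on L02 cells (Homo sapiens) for inhibition, read by MTT assay, with a stated time of 48 h (a higher number here means a weaker inhibitor, a lower number a stronger inhibitor), compound 1 reaches only a limit of the assay, > 200000 nM. Compound 2 `COc1ccc2c(=O)c(/C=C/C(=O)Nc3cc(C)ccc3C)coc2c1` likewise gives a limit in this assay, > 200000 nM. Compound 3 `COc1ccc2c(=O)c(/C=C/C(=O)NCc3ccc(F)cc3)coc2c1` also gives a limit, > 200000 nM. Thus the limit of > 200000 nM in this assay, at which 3 of the 3 values shown sit, covers every measured compound, and the steps a step that the two limits leave unreadable from compound 1 to compound 2, a step that the two limits leave unreadable from compound 1 to compound 3 and a step that the two limits leave unreadable from compound 2 to compound 3 cannot be sized. Compound 4 `COc1ccc2c(=O)c(/C=C/C(=O)NCc3ccccc3F)coc2c1` differs from compound 1 by 2-fluorobenzyl in place of 3-chlorophenyl on an amide-type nitrogen. Because a step that the two limits leave unreadable from compound 1 to compound 3 also brings in a benzyl group and ends at the limit, compound 4 is expected to stay there as well, with no readable step. The expected step is a step that the limit leaves unreadable from compound 1 to compound 4. Compound 4 is estimated at 250000 nM, between 100000 nM and 1000000 nM.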

Compound 4, half-maximal inhibitory concentration: > 200000 nM
Compound 4: only a limit was reported; the forecaster's own chance of this, stated with the estimate: 85%; the middle value is on the limit's open side.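

Compound 4 also sits at a limit of the assay, so its steps from compound 1, compound 2 and compound 3 cannot be read: the limit of > 200000 nM in this assay, at which 4 of the 4 values shown sit. The compounds shown leave open which group on the amide nitrogen, if any, would give a measurable value in this assay.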